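This account rests on a few compounds, and the source may have more. Where it says the series, first, only, none or still open, it means among the compounds named here.

In a functional assay on Rec1 cells (Homo sapiens) for inhibition, read by MTT assay, with a stated time of 48 h (a lower number here means a stronger inhibitor of growth, a higher number a weaker inhibitor of growth), compound 1 `Nc1nc(Nc2ccccc2)nc2[nH]c(=O)c(-c3c(Cl)cccc3Cl)cc12` gives only a limit, > 100000 nM, and not a number. Compound 2 `CN1C(=O)C(c2c(Cl)cccc2Cl)Cc2c(N)nc(Nc3ccccc3)nc21` does give a number, 1300 nM. Compound 3 `Cn1c(=O)c(-c2c(Cl)cccc2Cl)cc2c(N)nc(Nc3ccccc3)nc21` differs from compound 1 by a single change: methyl in place of hydrogen on an aromatic nitrogen. For the measured compounds named here, no measured step shows what this change does in this assay, so the expectation leans on compound 2 at 1300 nM, the only number available. The expected move, an at least 100-fold lower number from compound 1 to compound 3 (2.00 log units; beyond the scatter), is large and toward stronger inhibition of growth. Compound 3 is estimated at 1000 nM, with an expected range of 150 nM to 10000 nM.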

Compound 3, concentration for 50% growth inhibition: 700 nM
For compound 3 the middle estimate is 1.4-fold (0.15 log units) above the measured one; the range from low to high includes it.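

Methyl in place of hydrogen on the aromatic nitrogen is the first single change here with a readable effect: in this assay it gives an at least 140-fold lower number from compound 1 to compound 3 (2.15 log units; beyond the scatter) and turns a limit into a real number. That step is only a minimum, since compound 1 gives a limit and not a number: the limit of > 100000 nM in this assay, at which 1 of the 3 values shown sits. In this pair, then, what sits on this nitrogen decides whether a number can be read at all. Going by these compounds, what a larger group on the same nitrogen, such as an ethyl or a chain ending in an amine, would do in this assay stays open.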